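Cyclohexylcarbamoyl in place of methyl on the aryl oxygen

The compounds below may be only part of what the source reports. "The series", "measured", "known", "first", "only" and "open" are said of these compounds alone.

Compound 1 `COc1cccc(-c2c(C(=O)NCCCCCc3ccccc3)cc(C)n2Cc2ccccc2)c1` carries the phenyl on the shorter chain. In an assay (brain) for inhibition of Fatty-acid amide hydrolase 1 (Mus musculus), with stated times of 20 min and 15 min (a lower number here means a stronger inhibitor, a higher number a weaker inhibitor), compound 1 gives only a limit, > 50000 nM. Compound 2 `COc1cccc(-c2c(C(=O)NCCCCCCc3ccccc3)cc(C)n2Cc2ccccc2)c1` likewise gives only a limit in this assay, > 200 nM. For the measured compounds named here, the single measured step, a step that the two limits leave unreadable from compound 1 to compound 2, cannot be sized, since both values sit at limits (the limit of > 200 nM in this assay, at which 1 of the 2 values shown sits, (the limit of > 50000 nM in this assay, at which 1 of the 2 values shown sits)); compound 2 therefore stands at a limit and cannot be ordered against compound 1 in this assay. Compound 3 `Cc1cc(C(=O)NCCCCCCc2ccccc2)c(-c2cccc(OC(=O)NC3CCCCC3)c2)n1Cc1ccccc1` differs from compound 2 in cyclohexylcarbamoyl in place of methyl on an oxygen on an aromatic ring. Going by the values given here, no measured step touches this oxygen: the one step concerns the chain carrying the phenyl, and it is unreadable. The expectation for this assay is thus set without a measured anchor. The expected step is an at least 10-fold lower number from compound 2 to compound 3 (1.00 log units; beyond the scatter). Compound 3 is estimated at 20 nM in this assay, with a range from 1 nM to 500 nM.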

Compound 3, half-maximal inhibitory concentration: > 200 nM
Compound 3: no number, only a limit; the forecaster's own chance of this, stated with the estimate: 10%; at least 10-fold (1.00 log units) between middle value and limit.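

For the compounds shown here, compound 3 gives only a limit in this assay, > 200 nM, as does compound 2, so no step between compound 2 and compound 3 can be read. Still open, going by these compounds, is whether cyclohexylcarbamoyl in place of methyl on an oxygen on an aromatic ring changes inhibition at all, and in which direction.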